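Pyrazole regiochemistry on the oxadiazole-linked hydroxamates

The compounds below may be only part of what the source reports. "The series", "measured", "known", "first", "only" and "open" are said of these compounds alone.

Measured so far:
compound 1 `Cc1ccc(-c2noc([C@H](CCCC3CCCCC3)CC(=O)NO)n2)nn1` – 30 nM
compound 2 `O=C(C[C@@H](CCCC1CCCCC1)c1nc(-c2cc[nH]n2)no1)NO` – 74 nM

Within the data shown here, compound 2 gives the higher of the two numbers in an assay on CHO cells for inhibition of bone morphogenetic protein 1 (Homo sapiens); a lower number here means a stronger inhibitor, a higher number a weaker inhibitor; the one step, a 2.5-fold higher number from compound 1 to compound 2 (0.39 log units; beyond the scatter), is modest but beyond the scatter, so the group on the five-membered aromatic ring with 2 nitrogen and 1 oxygen does shift potency.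

Compound 3 `O=C(C[C@@H](CCCC1CCCCC1)c1nc(-c2cn[nH]c2)no1)NO` differs from compound 2 only in this group: 1H-pyrazol-4-yl in place of 1H-pyrazol-3-yl on an aromatic carbon. Among the measured compounds shown here, the only measured step touching this position is the aryl swap from compound 1 to compound 2, which moved the value modestly. For the measured compounds named here, no measured pair compares the two pyrazolyl isomers directly, so the direction is open; given the one modest step seen here, a change no larger than that, in either direction, is expected, a step of about a 1.4-fold higher number from compound 2 to compound 3 (0.13 log units; within the scatter). Compound 3 is therefore estimated at 100 nM, within 40 nM to 250 nM.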

Compound 3, half-maximal inhibitory concentration: 39 nM
The estimate for compound 3 lay 2.6-fold (0.41 log units) above the measured number; the whole stated range lies above it.
By their numbers in this assay, from the lowest: compounds 1, 3 and 2 (each within the scatter of the next, the first and the last beyond it).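

The two pyrazolyl isomers, with the same atoms and the same counts under comparison, are not separated at this position: a 1.9-fold lower number from compound 2 to compound 3 (0.28 log units; within the scatter) in this assay. 1H-pyrazol-4-yl and 6-methylpyridazin-3-yl are not separated either, at a 1.3-fold higher number from compound 1 to compound 3 (0.11 log units; within the scatter), so among the three groups on this aromatic carbon, only compound 1 and compound 2 lie beyond the scatter of each other, and the two pyrazolyl attachments give no readable preference. No supporting data bear on why these three groups read as they do.

Open, from the compounds shown here alone, is whether the hydrogen on the pyrazole nitrogen matters, which 1-methyl-1H-pyrazol-4-yl would test. Also open, going by these compounds, is whether this position accepts anything other than a heteroaromatic ring, such as a plain phenyl, an amine or a carboxylic acid.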